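Chloro to Dimethylamino: an Expected Cytotoxicity for Compound 4

The compounds below may be only part of what the source reports. "The series", "measured", "known", "first", "only" and "open" are said of these compounds alone.

Of the compounds shown here, three built on one shared core have been tested in a functional assay on MCF7 cells (Homo sapiens) for cytotoxicity, read by neutral red uptake, with a stated time of 3 days; a lower number here means a stronger inhibitor, a higher number a weaker inhibitor. Compound 1 `CCc1c(F)c(N)c2c(=O)cc(-c3ccc(N)c(F)c3)oc2c1F` gives 130 nM, compound 2 `CCCCc1c(F)c(N)c2c(=O)cc(-c3ccc(N)c(F)c3)oc2c1F` gives 8800 nM, and compound 3 `Nc1ccc(-c2cc(=O)c3c(N)c(F)c(Cl)c(F)c3o2)cc1F` gives 210 nM. Compound 3 therefore stands second highest of the three numbers, close to compound 1 and far from compound 2. The measured steps bracket the effect of the group at this position: a 1.6-fold higher number from compound 1 to compound 3 (0.21 log units; within the scatter) shows that chloro and ethyl are interchangeable within the scatter, whereas a 68-fold higher number from compound 1 to compound 2 (1.83 log units; beyond the scatter) and a 42-fold lower number from compound 2 to compound 3 (1.62 log units; beyond the scatter) show that butyl is tolerated poorly. Compound 4 `CN(C)c1c(F)c(N)c2c(=O)cc(-c3ccc(N)c(F)c3)oc2c1F` carries dimethylamino in place of chloro on an aromatic carbon. Dimethylamino brings three heavy atoms, more than chloro and comparable to ethyl but fewer than butyl, so the outcome is expected to lie between the small steps and the large ones. Compound 4 is thus estimated at 450 nM, with a plausible range from 120 nM to 2500 nM, implying an expected step of a 2.1-fold higher number from compound 3 to compound 4 (0.33 log units; beyond the scatter) in this assay, a modest weakening rather than a collapse.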

Compound 4, half-maximal inhibitory concentration: 39 nM
For compound 4 the middle estimate is 12-fold (1.06 log units) above the measured one, and the stated range ends above it.
By their numbers in this assay, from the lowest: compound 4; then compounds 1 and 3 (each within the scatter of the next); then compound 2.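

In this assay the dimethylamino group on this aromatic carbon, ortho to two fluoro groups, gives a 5.4-fold lower number from compound 3 to compound 4 (0.73 log units; beyond the scatter) and a 3.3-fold lower number from compound 1 to compound 4 (0.52 log units; beyond the scatter) and also a 230-fold lower number from compound 2 to compound 4 (2.35 log units; beyond the scatter) in the series. Until now the groups at this position had either matched each other within the scatter or, with butyl, raised the number, so this is the first change here to lower it beyond the scatter against every other group shown, and it also shows that more heavy atoms than chloro need not raise the number. No measured evidence explains this change.

The compounds shown leave open whether the lower number follows the nitrogen on the aromatic carbon or its two methyl groups, a question that methylamino, methoxy or isopropyl at this position would address. They also leave open how a cyclic amine such as pyrrolidine or morpholine would compare there.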